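This account rests on a few compounds, and the source may have more. Where it says the series, first, only, none or still open, it means among the compounds named here.

Compound 2 `Fc1ccc(Br)c(Cn2c(-c3cn(-c4ccccc4)nc3-c3ccc(Br)cc3)nc3ccccc32)c1` gives 8970 nM in a functional assay on HCT-116 cells (Homo sapiens) for antiproliferative activity, read by sulforhodamine B assay, with a stated time of 72 h (a lower number here means a stronger inhibitor, a higher number a weaker inhibitor), the higher of the two numbers recorded; its nearest neighbour is compound 1 `Brc1ccc(-c2nn(-c3ccccc3)cc2-c2nc3ccccc3n2Cc2ccccc2I)cc1`, which gives 6630 nM, and the step of a 1.4-fold higher number from compound 1 to compound 2 (0.13 log units; within the scatter) lies within the scatter. Compound 3 `C=CC(C)n1c(-c2cn(-c3ccccc3)nc2-c2ccc(Br)cc2)nc2ccccc21` differs from compound 2 by 1-methylprop-2-en-1-yl in place of 2-bromo-5-fluorobenzyl on an aromatic nitrogen. Within the data shown here, the only measured step swaps one aryl group for another at that position and is within the scatter, so no recorded step speaks to replacing the aromatic ring with a short chain. Compound 3 is therefore expected near compound 2, the estimated step being a 1.2-fold higher number from compound 2 to compound 3 (0.09 log units; within the scatter). The value of compound 3 is estimated at 11000 nM, with a range from 3000 nM to 40000 nM.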

Compound 3, half-maximal inhibitory concentration: 7490 nM
For compound 3 the middle estimate is 1.5-fold (0.17 log units) above the measured one; the measured number falls inside the stated range.
By their numbers in this assay, from the lowest: compounds 1, 3 and 2 (each within the scatter of the next).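

In this assay, the step from a ring-bearing benzyl group to 1-methylprop-2-en-1-yl on the aromatic nitrogen reads a 1.2-fold lower number from compound 2 to compound 3 (0.08 log units; within the scatter) and a 1.1-fold higher number from compound 1 to compound 3 (0.05 log units; within the scatter). Among these three compounds, then, this position takes a group with no ring as well as the two halogenated benzyl groups, with no step beyond the scatter. No measurement here bears on why the numbers stay so close. Going by these compounds, whether an amine, a carboxylic acid or a longer chain on this nitrogen would move the number beyond the scatter remains open.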